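A Chloro Added Beside Nothing Known: Compound 3 Awaits Measurement

A few compounds are considered here, and "the series" means these few. Any claim that something is new, unique, unknown or untested is made for them only; others in the source may bear on it.

Measured so far in a functional assay on HT-29 cells (Homo sapiens) for inhibition, read by sulforhodamine B assay, with a stated time of 48 h; a higher number here means a weaker inhibitor of growth, a lower number a stronger inhibitor of growth:
compound 1, `O=C(Nc1cccc(-n2cc(-c3ccncc3)c(-c3ccc(Cl)c(O)c3)n2)c1)Nc1cccc(C(F)(F)F)c1`: > 32500 nM
compound 2, `O=C(Nc1cccc(-n2cc(-c3ccncc3)c(-c3ccc(Cl)c(O)c3)n2)c1)Nc1cc(C(F)(F)F)cc(C(F)(F)F)c1`: 1870 nM.

For compound 1 the value is only a limit of this assay, > 32500 nM (the limit of > 32500 nM in this assay, at which 1 of the 2 values shown sits). Compound 2 gives 1870 nM in this assay. Within the data shown here, the single measured step, an at least 17-fold lower number from compound 1 to compound 2 (1.24 log units; beyond the scatter), shows a large gain on adding a group to this ring. Compound 3, `O=C(Nc1cccc(-n2cc(-c3ccncc3)c(-c3ccc(Cl)c(O)c3)n2)c1)Nc1ccc(Cl)c(C(F)(F)F)c1`, differs from compound 1 by chloro in place of hydrogen on an aromatic carbon. Because an at least 17-fold lower number from compound 1 to compound 2 (1.24 log units; beyond the scatter) was large, a lower number is expected for compound 3, though a smaller step. Compound 3 is expected at 6000 nM, between 2000 nM and 25000 nM, a step of an at least 5.4-fold lower number from compound 1 to compound 3 (0.73 log units; beyond the scatter).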

Compound 3, concentration for total growth inhibition: 5730 nM
The estimate for compound 3 lay 1.0-fold (0.02 log units) above the measured number; measured number inside the range.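

On the 3-(trifluoromethyl)phenyl ring, chloro ortho to the trifluoromethyl group also brings a gain in this assay, with an at least 5.6-fold lower number from compound 1 to compound 3 (0.75 log units; beyond the scatter). The step is only a bound, as compound 1 stands at a limit of the assay: the limit of > 32500 nM in this assay, at which 1 of the 3 values shown sits. The earlier compounds shown here showed such a gain only for a second trifluoromethyl group, whereas here a single chlorine atom at a different place on the ring also gives a number within the assay's range. As far as these compounds go, whether fluoro, methoxy or an amine at this position would do the same remains open. So does what chloro here gives without the trifluoromethyl group.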